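This account rests on a few compounds, and the source may have more. Where it says the series, first, only, none or still open, it means among the compounds named here.

Measured compounds:
compound 1 `CCCNCc1nnc(Nc2nc(C)nc3c2c(C)nn3-c2ccc(OC)cc2C)o1` gives 996 nM in a functional assay on CHO cells for antagonist activity at corticotropin-releasing factor receptor 1 (Homo sapiens), read by cAMP accumulation; a lower number here means a stronger inhibitor, a higher number a weaker inhibitor.
compound 2 `CC[C@@H](COC)Nc1nc(C)nc2c1c(C)nn2-c1ccc(OC)cc1C` gives 135 nM in this assay.

For the measured compounds named here, compound 1 has the higher of the two numbers; the only measured step from it, a 7.4-fold lower number from compound 1 to compound 2 (0.87 log units; beyond the scatter), replaced the five-membered ring on the ring nitrogen with a short branched chain. Compound 3 `CCC[C@H](CO)Nc1nc(C)nc2c1c(C)nn2-c1ccc(OC)cc1C` makes a similar change: 1-(hydroxymethyl)butyl in place of 5-((propylamino)methyl)-1,3,4-oxadiazol-2-yl on a nitrogen on an aromatic ring. Going by the values given here, only that one step bears on it, and it was of modest size toward a lower number. A lower number of comparable size is therefore expected for compound 3 in this assay, giving a step of a 6.6-fold lower number from compound 1 to compound 3 (0.82 log units; beyond the scatter). The estimate for compound 3 is 150 nM, with a range from 50 nM to 500 nM.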

Compound 3, inhibition constant: 76 nM
For compound 3 the middle estimate is 2.0-fold (0.30 log units) above the measured one; the measured number falls inside the stated range.
By their numbers in this assay, from the lowest: compounds 3 and 2 (each within the scatter of the next); then compound 1.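

A second open-chain group on the nitrogen gives a 13-fold lower number from compound 1 to compound 3 (1.12 log units; beyond the scatter) and so the gain seen with compound 2 is not confined to a single chain. The 1-(hydroxymethyl)butyl and 1-(methoxymethyl)propyl groups cannot be told apart here, with a 1.8-fold lower number from compound 2 to compound 3 (0.25 log units; within the scatter) and so a free hydroxyl and a methyl ether at the chain end both fit at this position. Nothing available explains why either chain outperforms the 5-((propylamino)methyl)-1,3,4-oxadiazol-2-yl group.

On these data alone, whether the chain needs an oxygen at all remains open. A plain alkyl chain, or an amine in place of the hydroxyl, would address that.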